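Replacing the urea nitrogen of compound 3 with a tert-butyl group

The source may report more compounds than this note shows. Statements on the series, on what has been measured and on what is new or still open speak of the compounds shown alone.

Measured compounds:
Compound 1, `O=S(=O)(c1cccc(F)c1)c1ccc2c(c1)CCC[C@H]2CN1CC(O)C1`: 0.1 nM
Compound 2, `N=C(N)NC(=O)C[C@@H]1CCCc2cc(S(=O)(=O)c3cccc(F)c3)ccc21`: 0.631 nM
Compound 3, `CN(C)C(=O)NC[C@@H]1CCCc2cc(S(=O)(=O)c3cccc(F)c3)ccc21`: 2.51 nM

In an assay on isolated protein for displacement of a labelled ligand from 5-hydroxytryptamine receptor 6 (Homo sapiens) (on this read-out higher numbers stand for weaker inhibition and lower numbers for stronger inhibition), compound 3 gives the highest of the three numbers. The change from compound 1 to compound 3, a 25-fold higher number from compound 1 to compound 3 (1.40 log units; beyond the scatter), is large, and the change from compound 2 to compound 3, a 4.0-fold higher number from compound 2 to compound 3 (0.60 log units; beyond the scatter), is modest; compound 3 therefore stands apart from both, with compound 2 nearer to it than compound 1.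

Compound 4, `CC(C)(C)C(=O)NC[C@@H]1CCCc2cc(S(=O)(=O)c3cccc(F)c3)ccc21`, differs from compound 3 only at the carbonyl: tert-butyl in place of dimethylamino on a carbonyl carbon. Within the data shown here, none of the measured steps alters the substituent on this carbonyl carbon; all three concern the whole group attached to the chain carbon on the saturated ring. The measured steps thus give no direct guide, and in this assay the expected step is a 1.2-fold higher number from compound 3 to compound 4 (0.08 log units; within the scatter), with no direction favoured beyond the scatter. Compound 4 is estimated at 3 nM, within a range of 1 nM to 10 nM.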

Compound 4, inhibition constant: 3.98 nM
Beside the measured number, compound 4's estimate is 1.3-fold (0.12 log units) below it; measured number inside the range.
By their numbers in this assay, from the lowest: compound 1; then compound 2; then compounds 3 and 4 (each within the scatter of the next).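

In this assay, among these compounds, tert-butyl in place of dimethylamino on a carbonyl carbon gives a 1.6-fold higher number from compound 3 to compound 4 (0.20 log units; within the scatter), so for the first time a change confined to this substituent is seen, and exchanging a group with nitrogen for one of carbon alone leaves no readable difference. The larger gaps persist with this new substituent, with a 6.3-fold higher number from compound 2 to compound 4 (0.80 log units; beyond the scatter) and a 40-fold higher number from compound 1 to compound 4 (1.60 log units; beyond the scatter) as the steps that stay readable. No available evidence accounts for this outcome.

The compounds shown leave open whether a smaller group such as methyl, or a ring such as cyclopropyl or morpholine, would behave the same way on this carbonyl carbon. They also leave open whether a primary amine or a carboxylic acid there would give a readable step.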